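Bromo for Amino on a Bis-pyridyl Hydrazone Core

A few compounds are considered here, and "the series" means these few. Any claim that something is new, unique, unknown or untested is made for them only; others in the source may bear on it.

Compound 1 `Nc1ccc(C(=O)NN=C(c2ccccn2)c2ccccn2)cc1`: 7640 nM
Compound 2 `O=C(N/N=C/c1ccccn1)c1ccc(C(F)(F)F)cc1`: 22400 nM
Compound 3 `O=C(N/N=C/c1ccccn1)c1ccc(O)cc1`: > 80000 nM

In an ADME assay on cells (Homo sapiens) for antiproliferative activity, read by MTT assay (a lower number here means a stronger inhibitor, a higher number a weaker inhibitor), compound 1 gives 7640 nM, the lowest of the two numbers reported. Compound 2 gives a higher number, 22400 nM, beyond the scatter of compound 1. Compound 3 reaches only a limit of the assay, > 80000 nM, and no number. Going by the values given here, the one step that can be measured runs from the trifluoromethyl of compound 2 to the hydroxy of compound 3, and it gave an at least 3.5-fold higher number from compound 2 to compound 3 (0.55 log units; beyond the scatter), ending at the limit (the limit of > 80000 nM in this assay, at which 1 of the 3 values shown sits).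

Compound 4 `O=C(NN=C(c1ccccn1)c1ccccn1)c1ccc(Br)cc1` has not been measured in this assay. It differs from compound 1 in one place: bromo in place of amino on an aromatic carbon. Among the compounds with values here, no measured step exchanges amino for bromo, and the only measured step concerns a different pair of groups on a different core, so it bears on this change only loosely. What the two cores share is that the compound without a hydrogen-bond donor on its aryl ring, compound 2, sits higher than compound 1. The step is therefore expected to be small to modest, toward a higher number, a 1.4-fold higher number from compound 1 to compound 4 (0.16 log units; within the scatter). Compound 4 is estimated at 11000 nM, within 3500 nM to 40000 nM.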

Compound 4, half-maximal inhibitory concentration: 300 nM
Estimate against measurement, compound 4: 37-fold (1.56 log units) above, and the stated range ends above it.
By their numbers in this assay, from the lowest: compound 4; then compound 1; then compound 2. At a limit, above all of these: compound 3.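

In this assay, bromo in place of amino on the shared core gave the first step measured on this core (a 25-fold lower number from compound 1 to compound 4 (1.41 log units; beyond the scatter)), and it is a large one. Going by these compounds alone, it shows that the group on this aromatic carbon, para to a large group, is not a matter of indifference on the core of compound 1: a single exchange, 4-aminophenyl to 4-bromophenyl, moves the number far beyond the scatter and toward a stronger inhibitor, against the direction the earlier compounds had suggested. Nothing at hand bears on why the exchange has this effect.

The compounds shown leave open whether the step belongs to bromo in particular or to the removal of amino, a question that chloro, fluoro or methyl at the same place on the core of compound 1 would address. They also leave open whether the same exchange carries over to the core of compound 2 and compound 3, where bromo would stand in place of trifluoromethyl or hydroxy.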